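The source may hold more compounds than are shown below. What is called first, only, known or untested is meant among the compounds shown, and "the series" means these compounds.

Compound 1 `CCCN(C)C(=O)c1ccc(-c2cc(-c3cc(OC)ccc3OC)no2)s1` gives > 30000 nM in a functional assay on PC-3 cells (Homo sapiens) for cytotoxicity, read by XTT assay, with a stated time of 72 h (a lower number here means a stronger inhibitor, a higher number a weaker inhibitor), which is a limit of the assay rather than a number.
Compound 2 `O=C1C=CC(=O)C(c2cc(-c3ccc(C(=O)N4CCCCC4)s3)on2)=C1` gives > 30000 nM in this assay, likewise a limit.
Compound 3 `CCCN(C)C(=O)c1ccc(-c2cc(C3=CC(=O)C=CC3=O)no2)s1` gives < 30000 nM in this assay, again a limit.

So compound 1 stands at the upper limit, where (the limit of > 30000 nM in this assay, at which 2 of the 3 values shown sit), and no number for it is known. Compound 4 `COc1ccc(OC)c(-c2cc(-c3ccc(C(=O)N4CCCCC4)s3)on2)c1` differs from compound 1 by piperidin-1-yl in place of methyl(propyl)amino on a carbonyl carbon. Among the measured compounds shown here, the only measured step touching this change runs the other way: a number no higher from compound 2 to compound 3 (the limit leaves the size open), its size not readable because only limits were reported. Read backwards, exchanging methyl(propyl)amino for piperidin-1-yl brought no gain in that pair, so for compound 4 no step beyond the scatter is expected, a step that the limit leaves unreadable from compound 1 to compound 4. Compound 4 is estimated at 40000 nM, within 15000 nM to 150000 nM, most likely again reported only as a limit.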

Compound 4, half-maximal inhibitory concentration: > 30000 nM
Compound 4 gave a limit, no number; the forecaster's own chance of this, stated with the estimate: 85%; the middle value does not contradict the limit.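

No step can be read from compound 1 to compound 4, since each is reported only as a limit and not as a number. The compounds shown leave open how much piperidin-1-yl and methyl(propyl)amino on a carbonyl carbon really differ.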